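Ester ring swap: cyclohexyl to cyclobutylmethyl, near-zero inhibition

The source may report more compounds than this note shows. Statements on the series, on what has been measured and on what is new or still open speak of the compounds shown alone.

Measured compounds:
Compound 1, `CCNC(=O)C1=C(C)NC(=O)NC1c1ccco1` — 2%
Compound 2, `CC1=C(C(=O)OC2CCCCC2)C(c2ccco2)NC(=O)N1` — 1%

Both measured compounds share the same core and differ only at the carbonyl carbon, where compound 1 carries ethylamino and compound 2 cyclohexyloxy. In an assay on membranes from CHO cells for displacement of a labelled ligand from adenosine receptor A1 (Homo sapiens), read by scintillation counting, with a stated time of 60 min, tested at 1 uM (a higher number here means more inhibition at the concentration tested (going by the name of the read-out), a lower number less inhibition), compound 1 gives 2% and compound 2 gives 1%; the step of a number 1 percentage points lower from compound 1 to compound 2 (within the scatter) is within the scatter, so the two numbers cannot be told apart, and both show almost no inhibition. Compound 2 therefore stands at a near-zero value that is indistinguishable from that of compound 1.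

Compound 3, `CC1=C(C(=O)OCC2CCC2)C(c2ccco2)NC(=O)N1`, differs from compound 2 in one place: cyclobutylmethyl in place of cyclohexyl on an oxygen next to a carbonyl group. For the measured compounds named here, no measured step covers this exact exchange; the only step touching the same place, from compound 1 to compound 2, was within the scatter. With both neighbours near zero, compound 3 is expected to show no step beyond the scatter: a number 1 percentage points higher from compound 2 to compound 3 (within the scatter). Compound 3 is thus estimated at 2%, in the range -8% to 12%.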

Compound 3, a percentage reported as inhibition, at one concentration (the size of the read-out at that concentration, not a potency): 42%
Beside the measured number, compound 3's estimate is 40 percentage points below it; measured number outside the range, above it.
By their numbers in this assay, from the lowest: compounds 2 and 1 (each within the scatter of the next); then compound 3.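

In this assay, this place on the ester proves sensitive to the group it carries: cyclobutylmethyl in place of cyclohexyl on an oxygen next to a carbonyl group gives a number 41 percentage points higher from compound 2 to compound 3 (beyond the scatter) and lifts inhibition clear of the near-zero level. The earlier pair had suggested no response, but cyclobutylmethoxy in place of ethylamino on a carbonyl carbon gives a number 40 percentage points higher from compound 1 to compound 3 (beyond the scatter) and shows that the result depends on the exact group, not simply on having an ester rather than an amide. No measured evidence is available to explain this jump.

Cyclobutylmethyl differs from cyclohexyl in both its ring and the link to that ring, so cyclobutyl or cyclohexylmethyl on the same oxygen would be needed to separate the two changes. Going by these compounds, whether an open chain such as n-butyl would serve as well also remains open.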